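The source may report more compounds than this note shows. Statements on the series, on what has been measured and on what is new or still open speak of the compounds shown alone.

Compound 1 `COc1ccc([C@H]2O[C@@H](c3cc(OC)c(O)c(OC)c3)[C@H](C)[C@@H]2C)cc1OC`: 101000 nM
Compound 2 `COc1ccc([C@H]2O[C@@H](c3cc(OC)c(OC)c(OC)c3)[C@H](C)[C@@H]2C)cc1OC`: 172000 nM
Compound 3 `COc1cc(C(=O)[C@@H](C)Oc2c(OC)cc(/C=C/CO)cc2OC)cc(OC)c1OC`: > 200000 nM

All three were tested in an ADME assay on P3HR-1 cells (Homo sapiens) for cytotoxicity, read by microscopy and trypan blue exclusion, with a stated time of 2 days; a higher number here means that more compound is tolerated, a lower number that less compound is tolerated. Compound 1 gives 101000 nM and compound 2 gives 172000 nM. Compound 3 gives > 200000 nM, which is a limit of the assay rather than a number. Among the two numbers, compound 2 has the higher one, but a 1.7-fold higher number from compound 1 to compound 2 (0.23 log units; within the scatter), so compound 1 and compound 2 cannot be told apart on these data.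

Compound 4 `COc1cc([C@H]2O[C@@H](c3cc(OC)c(OC)c(OC)c3)[C@H](C)[C@@H]2C)cc(O)c1OC` is not yet measured. It differs from compound 2 by hydroxy in place of hydrogen on an aromatic carbon. Among the measured compounds shown here, the only measured step that bears on a change of this kind is a 1.7-fold higher number from compound 1 to compound 2 (0.23 log units; within the scatter), where a hydroxy was exchanged for a methoxy on an aromatic ring without a shift beyond the scatter. By the same reasoning, adding a hydroxy to compound 2 is expected to give no step beyond the scatter, a 1.3-fold lower number from compound 2 to compound 4 (0.12 log units; within the scatter). Compound 4 is therefore estimated at 130000 nM, with a range from 60000 nM to 200000 nM.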

Compound 4, half-maximal cytotoxic concentration: 32000 nM
The estimate for compound 4 lay 4.1-fold (0.61 log units) above the measured number; measured number outside the range, below it.
By their numbers in this assay, from the lowest: compound 4; then compounds 1 and 2 (each within the scatter of the next). At a limit, above all of these: compound 3.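

This carbon matters in this assay: placing a hydroxy on it, ortho to a methoxy group, gives a 5.4-fold lower number from compound 2 to compound 4 (0.73 log units; beyond the scatter) and so less compound is tolerated. The earlier pair could not show this, as the exchange of a hydroxy for a methoxy at another place gave a 1.7-fold higher number from compound 1 to compound 2 (0.23 log units; within the scatter) and therefore no shift that could be told from the scatter. A hydroxy thus does not leave the number unchanged at every place on these compounds, and nothing measured here accounts for the step.

Still open, from the compounds shown here alone, is whether this step belongs to the hydroxy itself or whether an amine, a carboxylic acid or a fluorine on the same carbon would give a similar one. Also open, going by these compounds, is whether the hydroxy would have the same effect with the other substituents changed.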